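Amide aryl variation on a shared core: working notes

This account rests on a few compounds, and the source may have more. Where it says the series, first, only, none or still open, it means among the compounds named here.

Measured so far in a functional assay on HepG2 cells (Homo sapiens) for inhibition, read by MTT assay; a higher number here means a weaker inhibitor, a lower number a stronger inhibitor:
compound 1, `COc1cc2ncnc(Nc3ccc(NC(=O)c4ccc(C)cc4)cc3)c2cc1OC`: 25000 nM
compound 2, `CCc1ccc(C(=O)Nc2ccc(Nc3ncnc4cc(OC)c(OC)cc34)cc2)cc1`: 72000 nM
compound 3, `COc1cc2ncnc(Nc3ccc(NC(=O)c4cccc(F)c4)cc3)c2cc1OC`: 8200 nM

Compound 2 stands highest of the three numbers in this assay; the step of a 2.9-fold higher number from compound 1 to compound 2 (0.46 log units; beyond the scatter) and the step of an 8.8-fold lower number from compound 2 to compound 3 (0.94 log units; beyond the scatter) both lie beyond the scatter.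

Compound 4, `COc1cc2ncnc(Nc3ccc(NC(=O)c4ccc(Cl)cc4)cc3)c2cc1OC`, differs from compound 2 by chloro in place of ethyl on an aromatic carbon. For the measured compounds named here, two steps bear on it: a 2.9-fold higher number from compound 1 to compound 2 (0.46 log units; beyond the scatter) shows the ethyl giving a higher number than methyl, and an 8.8-fold lower number from compound 2 to compound 3 (0.94 log units; beyond the scatter) shows that a halogen-bearing aryl gives a markedly lower number. Going by the values given here, no para-halogen analogue has been measured, so the expected step is set between these. Compound 4 is therefore expected to give 20000 nM in this assay, within 6000 nM to 60000 nM, an expected step of a 3.6-fold lower number from compound 2 to compound 4 (0.56 log units; beyond the scatter).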

Compound 4, half-maximal inhibitory concentration: 28000 nM
Beside the measured number, compound 4's estimate is 1.4-fold (0.15 log units) below it, and the stated range covers the measured number.
By their numbers in this assay, from the lowest: compound 3; then compounds 1 and 4 (each within the scatter of the next); then compound 2.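

In this assay, chloro in place of ethyl on this aromatic carbon lowers the number (a 2.6-fold lower number from compound 2 to compound 4 (0.41 log units; beyond the scatter)), yet chloro in place of methyl leaves it within the scatter (a 1.1-fold higher number from compound 1 to compound 4 (0.05 log units; within the scatter)). A halogen on the aryl therefore does not by itself give the low number of compound 3, as 4-chlorophenyl in place of 3-fluorophenyl shows (a 3.4-fold higher number from compound 3 to compound 4 (0.53 log units; beyond the scatter)). No supporting data bear on the reason for these steps.

Open, from the compounds shown here alone, is whether the low number of compound 3 follows fluoro or its ring place, which 4-fluorophenyl and 3-chlorophenyl would separate. Going by these compounds, an amine or a carboxylic acid on this carbon also remains open.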